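The compounds below may be only part of what the source reports. "The series", "measured", "known", "first", "only" and "open" are said of these compounds alone.

In an ADME assay on HEK293 cells (Homo sapiens) for cytotoxicity, read by MTT assay, with a stated time of 48 h (a higher number here means a weaker inhibitor, a lower number a stronger inhibitor), compound 1 (`O=C1/C(=C\c2ccccc2)S/C(=N/c2ccccc2)N1Cc1ccncc1`) gives 64700 nM and compound 2 (`CN(C)c1ccc(/C=C2/S/C(=N/c3ccccc3)N(Cc3ccncc3)C2=O)cc1`) gives 122000 nM. Among the measured compounds shown here, these are the only two numbers so far, and they lie within the usual scatter of each other, so compound 2 stands level with compound 1. Compound 3 (`COc1cc(/C=C2/S/C(=N/c3ccccc3)N(Cc3ccncc3)C2=O)ccc1O`) keeps the shared core and swaps one group: 4-hydroxy-3-methoxyphenyl in place of 4-(dimethylamino)phenyl on a double-bonded chain carbon bound to a double-bonded ring carbon. For the measured compounds named here, the one measured step that bears on this is a 1.9-fold higher number from compound 1 to compound 2 (0.28 log units; within the scatter), with dimethylamino in place of hydrogen on an aromatic carbon. Going by the values given here, that is thin evidence, since no compound carrying the hydroxy and methoxy groups has been measured. Among the compounds with values here, with only that step within the scatter to go on, no shift beyond the scatter is expected in this assay, and the estimated move is a 1.4-fold lower number from compound 2 to compound 3 (0.13 log units; within the scatter). Compound 3 is expected to give about 90000 nM, within an estimated range of 40000 nM to 200000 nM.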

Compound 3, half-maximal inhibitory concentration: 67400 nM
The estimate for compound 3 lay 1.3-fold (0.13 log units) above the measured number, and the stated range covers the measured number.
By their numbers in this assay, from the lowest: compounds 1, 3 and 2 (each within the scatter of the next).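

In this assay, the 4-hydroxy-3-methoxyphenyl group in place of 4-(dimethylamino)phenyl on a double-bonded chain carbon bound to a double-bonded ring carbon gives a 1.8-fold lower number from compound 2 to compound 3 (0.26 log units; within the scatter), and in place of phenyl it gives a 1.0-fold higher number from compound 1 to compound 3 (0.02 log units; within the scatter). Hydroxy and methoxy groups therefore join the dimethylamino group as changes at this position that produce no shift beyond the scatter, so all three compounds now stand level with one another. No measurement shown offers a reason for these numbers.

On these data alone, because hydroxy and methoxy entered together, the effect of each alone remains unknown. As far as these compounds go, it is also open whether a carboxylic acid on this aromatic ring, or a longer alkyl chain in its place, would move the number beyond the scatter.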